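The source may hold more compounds than are shown below. What is called first, only, known or untested is meant among the compounds shown, and "the series" means these compounds.

Compound 1 `COc1cc(-c2cc(/C=C/C(=O)c3ccc(N)cc3)[nH]n2)cc(OC)c1OC`, tested in a functional assay on OVCAR-3 cells (Homo sapiens) for inhibition, read by sulforhodamine B assay, with a stated time of 48 h (on this read-out higher numbers stand for lower toxicity in this test and lower numbers for higher toxicity in this test), gives 7260 nM. Compound 2 `COc1ccc(-c2cc(/C=C/C(=O)c3ccc(N)cc3)[nH]n2)cc1OC` differs from compound 1 by hydrogen in place of methoxy on an aromatic carbon; in this assay compound 2 gives 9140 nM, a step of a 1.3-fold higher number from compound 1 to compound 2 (0.10 log units; within the scatter). Compound 3 `COc1cc(C(=O)/C=C/c2cc(-c3cc(OC)c(OC)c(OC)c3)n[nH]2)cc(OC)c1OC` gives 5790 nM in this assay; the difference between its core and the core of compound 1 is not broken down here. Compound 4 `COc1ccc(-c2cc(/C=C/C(=O)c3cc(OC)c(OC)c(OC)c3)[nH]n2)cc1OC` is not yet measured. For the measured compounds named here, it differs from compound 3 by hydrogen in place of methoxy on an aromatic carbon, the same change in the same kind of place as the one from compound 1 to compound 2. The estimate for compound 4 in this assay is therefore a step of about a 1.3-fold higher number from compound 3 to compound 4 (0.11 log units; within the scatter), because the earlier step of a 1.3-fold higher number from compound 1 to compound 2 (0.10 log units; within the scatter) stayed within the scatter. Compound 4 is expected to give about 7500 nM, likely between 4000 nM and 14000 nM.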

Compound 4, concentration lethal to 50% of the cells: 6230 nM
The estimate for compound 4 lay 1.2-fold (0.08 log units) above the measured number, within the range that was stated.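

In this assay, replacing methoxy with hydrogen on the second core gives a 1.1-fold higher number from compound 3 to compound 4 (0.03 log units; within the scatter) and so leaves no readable change. Set beside the earlier case, the two steps agree: the same change on two cores in this assay, a 1.3-fold higher number (0.10 log units; within the scatter) from compound 1 to compound 2 and a 1.1-fold higher number (0.03 log units; within the scatter) from compound 3 to compound 4, 1.2-fold (0.07 log units) apart, within the scatter of two such steps. On these two cores, then, this swap carries over as a step too small to separate from ordinary repeat variation, but two small steps do not show that it would stay small on any other core, and they do not explain why it is small.

The compounds shown hold only methoxy or hydrogen at this place. On these data alone, how a fluorine atom, a carboxylic acid or a longer chain such as ethoxy would behave there remains open.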